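Aryl substituent change on the piperazine phenyl ring

This account rests on a few compounds, and the source may have more. Where it says the series, first, only, none or still open, it means among the compounds named here.

Measured so far:
compound 1 `COc1ccccc1N1CCN(CCCNc2ncccc2C(=O)NC(C)(C)C)CC1` in an assay on isolated protein for displacement of a labelled ligand from Alpha-1A adrenergic receptor (Bos taurus) (a higher number here means a weaker inhibitor, a lower number a stronger inhibitor), gives 1.59 nM
compound 2 `CN(C)C(=O)c1cccnc1NCCCN1CCN(c2ccccc2OCC2CC2)CC1` in this assay gives 0.0794 nM

Compound 2 stands lowest of the two numbers, with compound 1 the nearest neighbour at a gap that lies beyond the scatter. Compound 3 `Cc1ccccc1N1CCN(CCCNc2ncccc2C(=O)N(C)C)CC1` is the next candidate; relative to compound 2 it carries methyl in place of cyclopropylmethoxy on an aromatic carbon, on an aromatic carbon ortho to a large group. Going by the values given here, no comparable step among measured compounds exists. Given that compound 2 gives 0.0794 nM and both measured compounds hold an alkoxy group there, a sizeable weakening is expected for compound 3, estimated as a 13-fold higher number from compound 2 to compound 3 (1.10 log units; beyond the scatter). Compound 3 is thus expected at 1 nM, within 0.2 nM to 5 nM.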

Compound 3, inhibition constant: 0.794 nM
Compound 3: middle estimate off by 1.3-fold (0.10 log units), on the high side; low and high end bracket the measured number.
By their numbers in this assay, from the lowest: compound 2; then compounds 3 and 1 (each within the scatter of the next).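

Replacing cyclopropylmethoxy with methyl on an aromatic carbon ortho to a large group, with the rest of the molecule unchanged, gives a 10-fold higher number from compound 2 to compound 3 (1.00 log units; beyond the scatter) in this assay. This position therefore affects binding, yet an alkoxy group is not required there, as compound 3 still gives 0.794 nM. Nothing available bears on the origin of this step.

The change removes the ether oxygen, the three-membered ring and most of the group's size at once, so their contributions remain unseparated. Ethoxy or chlorine on this carbon remains an open comparison.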